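Aroyl variation on the shared core: an inactive pair

A few compounds are considered here, and "the series" means these few. Any claim that something is new, unique, unknown or untested is made for them only; others in the source may bear on it.

compound 1 `COc1cc(-c2nnc3n2NC(c2ccco2)C(C(=O)C2CC2)S3)cc(OC)c1OC`: > 100000 nM
compound 2 `COc1cccc(C(=O)C2Sc3nnc(-c4cc(OC)c(OC)c(OC)c4)n3NC2c2ccco2)c1`: > 100000 nM

In a functional assay on HepG2 cells (Homo sapiens) for cytotoxicity, read by MTT assay, with a stated time of 48 h (a lower number here means a stronger inhibitor, a higher number a weaker inhibitor), compound 1 gives only a limit, > 100000 nM. Compound 2 likewise gives only a limit, > 100000 nM. Among the measured compounds shown here, the single measured step, a step that the two limits leave unreadable from compound 1 to compound 2, cannot be sized, since both values sit at the limit of > 100000 nM in this assay, at which 2 of the 2 values shown sit. Compound 3 `COc1cc(-c2nnc3n2NC(c2ccco2)C(C(=O)c2cccc4ccccc24)S3)cc(OC)c1OC` differs from compound 2 by naphthalen-1-yl in place of 3-methoxyphenyl on a carbonyl carbon. No readable step bears on this change, so no movement beyond the scatter is foreseen, and a further limit is expected. Compound 3 is estimated at 150000 nM, with a range of 40000 nM to 500000 nM. The expected step is a step that the limit leaves unreadable from compound 2 to compound 3.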

Compound 3, half-maximal inhibitory concentration: 33900 nM
Beside the measured number, compound 3's estimate is 4.4-fold (0.65 log units) above it; the measured number lies below the stated range.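

Among the compounds shown here, compound 3 is the first in this set to give a number rather than a limit in this assay, so the group on the carbonyl carbon can shift this read-out. Naphthalen-1-yl in place of 3-methoxyphenyl gives an at least 2.9-fold lower number from compound 2 to compound 3 (0.46 log units; beyond the scatter), and naphthalen-1-yl in place of cyclopropyl gives an at least 2.9-fold lower number from compound 1 to compound 3 (0.46 log units; beyond the scatter). Both steps start from a limit, so each gives only a minimum size.

The compounds shown do not separate the effect of the second aromatic ring from that of losing the methoxy group. Going by these compounds, how an amine or a carboxylic acid on the aryl ring would read here remains open.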